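Ring-nitrogen substituent changes in the shared core

The source may hold more compounds than are shown below. What is called first, only, known or untested is meant among the compounds shown, and "the series" means these compounds.

compound 1 `NC(=O)c1c(NC(=O)c2ccccc2Cl)sc2c1CCN(Cc1ccccc1)C2`: 12000 nM
compound 2 `Cc1ccccc1CN1CCc2c(sc(NC(=O)c3ccccc3Cl)c2C(N)=O)C1`: > 50000 nM (a limit)
compound 3 `NC(=O)c1c(NC(=O)c2ccccc2Cl)sc2c1CCN(Cc1cc(Cl)cc(Cl)c1)C2`: 15800 nM

In a functional assay on HL-60 cells (Homo sapiens) for antiproliferative activity, with a stated time of 24 h (on this read-out higher numbers stand for weaker inhibition and lower numbers for stronger inhibition), compound 3 gives 15800 nM, the higher of the two numbers. Compound 1 gives 12000 nM, and a 1.3-fold higher number from compound 1 to compound 3 (0.12 log units; within the scatter) lies within the scatter. For compound 2 the assay reports only a limit, > 50000 nM. Compound 4 `NC(=O)c1c(NC(=O)c2ccccc2Cl)sc2c1CCN(C(=S)Nc1ccccc1F)C2` differs from compound 3 by a group of 10 heavy atoms (7 carbon, 1 nitrogen, 1 fluorine, 1 sulfur; one six-membered aromatic ring of carbon only) in place of a group of 9 heavy atoms (7 carbon, 2 chlorine; one six-membered aromatic ring of carbon only), on an amine nitrogen in a ring. The measured steps concern only the benzyl substituent on the ring nitrogen: an at least 4.1-fold higher number from compound 1 to compound 2 (0.61 log units; beyond the scatter), an at least 3.1-fold lower number from compound 2 to compound 3 (0.50 log units; beyond the scatter) and a 1.3-fold higher number from compound 1 to compound 3 (0.12 log units; within the scatter). None of them covers the group that enters here, so the expectation rests on the spread seen so far. For compound 4 the estimated step is a 1.1-fold lower number from compound 3 to compound 4 (0.02 log units; within the scatter), none beyond the scatter. Compound 4 is therefore expected near 15000 nM, with a range from 4000 nM to 50000 nM.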

Compound 4, half-maximal inhibitory concentration: 4970 nM
The estimate for compound 4 lay 3.0-fold (0.48 log units) above the measured number; the measured number falls inside the stated range.
By their numbers in this assay, from the lowest: compound 4; then compounds 1 and 3 (each within the scatter of the next). At a limit, above all of these: compound 2.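

Within the data shown here, on the amine nitrogen in a ring, the fluorine- and sulfur-bearing group of compound 4 is the first replacement for a benzyl-type substituent that lowers the number beyond the scatter from compound 1: a 2.4-fold lower number from compound 1 to compound 4 (0.38 log units; beyond the scatter). The same group also gains on the 3,5-dichlorobenzyl compound, with a 3.2-fold lower number from compound 3 to compound 4 (0.50 log units; beyond the scatter), so this position tolerates a substituent carrying a hydrogen-bond donor and a double bond outside aromatic rings. The comparison with compound 2, an at least 10-fold lower number from compound 2 to compound 4 (1.00 log units; beyond the scatter), has only a lower bound, and its size rests on a limit: the limit of > 50000 nM in this assay, at which 1 of the 4 values shown sits.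

Which part of the new group carries the change stays open. A urea oxygen in place of the sulfur, or an unsubstituted phenyl in place of the fluorophenyl, would separate these contributions.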